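The source may report more compounds than this note shows. Statements on the series, on what has been measured and on what is new or still open speak of the compounds shown alone.

- compound 1 `Cc1cccc(-c2cc(C)c(Oc3cc(N)nc(Nc4ccc(C#N)cc4)n3)c(C)c2)c1`: 27600 nM
- compound 2 `COc1cccc(-c2cc(C)c(Oc3cc(N)nc(Nc4ccc(C#N)cc4)n3)c(C)c2)c1`: 19300 nM

In a toxicity assay on MT4 cells (Homo sapiens) for cytotoxicity, read by MTT assay (on this read-out higher numbers stand for lower toxicity in this test and lower numbers for higher toxicity in this test), compound 2 gives 19300 nM, which lies within the scatter of compound 1. Compound 3 `Cc1cc(-c2ccc(C#N)c(F)c2)cc(C)c1Oc1cc(N)nc(Nc2ccc(C#N)cc2)n1` carries 4-cyano-3-fluorophenyl in place of 3-methoxyphenyl on an aromatic carbon. For the measured compounds named here, only one measured step bears on this group, a 1.4-fold lower number from compound 1 to compound 2 (0.16 log units; within the scatter), and it is small. Going by the values given here, it involves a methoxy and a methyl group, however, and no measured compound carries the nitrile or the fluorine of the new group. In this assay, no step beyond the scatter is therefore expected, though with wide uncertainty. The estimated step is a 1.2-fold lower number from compound 2 to compound 3 (0.08 log units; within the scatter). For compound 3 the expected value is 16000 nM, within an estimated range of 6000 nM to 45000 nM.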

Compound 3, half-maximal cytotoxic concentration: 5000 nM
Compound 3: middle estimate off by 3.2-fold (0.51 log units), on the high side, and the stated range ends above it.
By their numbers in this assay, from the lowest: compound 3; then compounds 2 and 1 (each within the scatter of the next).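

In this assay, this position proves able to move the number beyond the scatter: 4-cyano-3-fluorophenyl in place of 3-methoxyphenyl gives a 3.9-fold lower number from compound 2 to compound 3 (0.59 log units; beyond the scatter), and in place of 3-methylphenyl it gives a 5.5-fold lower number from compound 1 to compound 3 (0.74 log units; beyond the scatter). The exchange of methyl for methoxy had shown no such shift, so the read-out is not indifferent to every change in this group. No measurement shown here accounts for the shift. The nitrile and the fluorine enter together, and the compounds shown do not separate them. On these data alone, how an amine or a carboxylic acid on this ring would read also remains open.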